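Configuration at a chain stereocentre: working notes

The source may hold more compounds than are shown below. What is called first, only, known or untested is meant among the compounds shown, and "the series" means these compounds.

Measured in a functional assay on A549 cells (Homo sapiens) for antiproliferative activity, read by XTT assay, with a stated time of 72 h; on this read-out higher numbers stand for weaker inhibition and lower numbers for stronger inhibition:
- compound 1 `C=C(C)CCC[C@]1(C)C2=CCC[C@](C)(CC(=O)c3ccoc3)[C@H]2CC[C@H]1C`: > 100000 nM, a limit
- compound 2 `C=C(C)CC[C@]1(C)C2=CCC[C@](C)(C[C@H](O)c3ccoc3)[C@H]2CC[C@H]1C`: 34000 nM
- compound 3 `C=C(C)CCC[C@]1(C)C2=CCC[C@](C)(C[C@@H](O)c3ccoc3)[C@H]2CC[C@H]1C`: 66000 nM

Among the compounds with values here, compound 3 and compound 2 lie within the scatter of each other, and they hold the only two numbers. Compound 1 sits at the limit of > 100000 nM in this assay, at which 1 of the 3 values shown sits.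

Still unmeasured is compound 4 `C=C(C)CCC[C@]1(C)C2=CCC[C@](C)(C[C@H](O)c3ccoc3)[C@H]2CC[C@H]1C`. Its difference from compound 3 is confined to configuration: the two compounds have the same atoms and bonds and differ only in configuration as drawn: 1 of 5 stereo elements differ; a stereocentre at a saturated chain carbon is drawn R in compound 3 and S in compound 4.

Within the data shown here, only one measured step exists, an at least 1.5-fold lower number from compound 1 to compound 3 (0.18 log units; that floor lies within the scatter). That step puts (furan-3-yl)(hydroxy)methyl in place of (furan-3-yl)carbonyl, so it does not test configuration, and it rests on a limit. Among the measured compounds shown here, no measured step isolates this stereocentre. With compound 3 at 66000 nM as the starting point, no step beyond the scatter is expected in this assay, in either direction. The expected change is a 1.2-fold lower number from compound 3 to compound 4 (0.08 log units; within the scatter). For compound 4 the estimated value is 55000 nM. The expected range for compound 4 runs from 25000 nM to 110000 nM.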

Compound 4, half-maximal inhibitory concentration: 66000 nM
Compound 4: middle estimate off by 1.2-fold (0.08 log units), on the low side; the measured number falls inside the stated range.
By their numbers in this assay, from the lowest: compounds 2, 3 and 4 (each within the scatter of the next). At a limit, above all of these: compound 1.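

In this assay, moving the stereocentre at the saturated chain carbon from R to S gives no change at the digits printed from compound 3 to compound 4 (within the scatter), and this step reads configuration alone: the fact that compounds 3 and 4 differ only in the configuration as drawn. The 2-methylprop-2-en-1-yl chain of compound 4 in place of the 1-methylethenyl chain of compound 2 gives a 1.9-fold higher number from compound 2 to compound 4 (0.29 log units; within the scatter), so this chain change, with the configuration drawn alike, also shows no separation in this series. Compound 1 stands at a limit, and (furan-3-yl)(hydroxy)methyl in place of (furan-3-yl)carbonyl gives an at least 1.5-fold lower number from compound 1 to compound 4 (0.18 log units; that floor lies within the scatter), so the S alcohol, like the R alcohol, is not separated from the carbonyl compound on this read-out.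

From the compounds shown here alone, it remains open whether this stereocentre would matter with an amine or a methoxy group in place of the hydroxy group on that chain carbon. Going by these compounds, it is also open whether a carboxylic acid in place of the terminal alkene of the chain would change what either configuration gives.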